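The source may hold more compounds than are shown below. What is called first, only, known or untested is meant among the compounds shown, and "the series" means these compounds.

Measured in an ADME assay (liver) for pharmacokinetics, with Liver microsome (Rattus norvegicus) as the target, read by LC-MS, using microsomes, tested at 2 uM; on this read-out lower numbers stand for slow clearance and higher numbers for fast clearance:

Compound 1 `O=C(N[C@@H]1CCCC[C@H]1O)c1cnc(Oc2ccccc2)c(-c2ccc(Cl)cc2)c1`: 0.353 mL/min/kg
Compound 2 `Cc1cc(COc2ncc(C(=O)N[C@@H]3CCCC[C@H]3O)cc2-c2ccc(Cl)cc2)on1`: 0.151 mL/min/kg
Compound 3 `O=C(N[C@@H]1CCCC[C@H]1O)c1cnc(OCc2ccncc2)c(-c2ccc(Cl)cc2)c1`: 0.118 mL/min/kg

Compound 1 stands highest of the three numbers; both the step of a 2.3-fold lower number from compound 1 to compound 2 (0.37 log units; beyond the scatter) and the step of a 3.0-fold lower number from compound 1 to compound 3 (0.48 log units; beyond the scatter) run downward beyond the scatter, while the step of a 1.3-fold lower number from compound 2 to compound 3 (0.11 log units; within the scatter) lies within it. Compound 4 `O=C(N[C@@H]1CCCC[C@H]1O)c1cnc(OCc2ccccn2)c(-c2ccc(Cl)cc2)c1` differs from compound 1 by (pyridin-2-yl)methyl in place of phenyl on an oxygen on an aromatic ring. The two measured steps away from compound 1 both replace the phenyl with a methyl-linked heteroaromatic ring, and the step to compound 3 with (pyridin-4-yl)methyl is the closest analogue of the change to compound 4. A modest downward step beyond the scatter is therefore expected in this assay. Compound 4 is estimated at 0.14 mL/min/kg (range 0.08 mL/min/kg to 0.26 mL/min/kg). The expected step is a 2.5-fold lower number from compound 1 to compound 4 (0.40 log units; beyond the scatter).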

Compound 4, clearance: 0.044 mL/min/kg
Estimate against measurement, compound 4: 3.2-fold (0.50 log units) above, outside the stated range (below it).
By their numbers in this assay, from the lowest: compound 4; then compounds 3 and 2 (each within the scatter of the next); then compound 1.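

In this assay, among these compounds, the identity of the ring on the saturated chain carbon matters more than the earlier compounds suggested: (pyridin-2-yl)methyl gives the largest drop from the phenyl of compound 1 (an 8.0-fold lower number from compound 1 to compound 4 (0.90 log units; beyond the scatter)). The two pyridine isomers are also separated (a 2.7-fold lower number from compound 3 to compound 4 (0.43 log units; beyond the scatter)), and so are the pyridin-2-yl and 3-methyl-1,2-oxazol-5-yl groups (a 3.4-fold lower number from compound 2 to compound 4 (0.54 log units; beyond the scatter)), whereas compound 2 and compound 3 lay within the scatter of each other. No measurement at hand accounts for this difference between the groups.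

The data do not divide the drop between the added methyl link and the ring nitrogen. A plain phenylmethyl group would be needed to separate the two. Also open, from the compounds shown here alone, is whether pyridin-3-yl or a longer chain would follow compound 3 or compound 4.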